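Vero Cell Tolerance: From Compound 2 to Compound 4

This account rests on a few compounds, and the source may have more. Where it says the series, first, only, none or still open, it means among the compounds named here.

Compound 1 `C=CCN(CC=C)C(=S)N/N=C(/C)c1ccccc1`: 229000 nM
Compound 2 `Oc1ccccc1/C=N\NC(=S)N(Cc1ccccc1)Cc1ccccc1`: 166000 nM
Compound 3 `C/C(=N/NC(=S)N(Cc1ccccc1)Cc1ccccc1)c1ccc(O)cc1`: 160000 nM

Of the compounds shown here, three have so far been measured in an ADME assay on Vero cells (Chlorocebus sabaeus) for cytotoxicity, read by MTT assay, with a stated time of 72 h; a lower number here means that less compound is tolerated, a higher number that more compound is tolerated. In this assay compound 1 gives 229000 nM, compound 2 gives 166000 nM, and compound 3 gives 160000 nM. Compound 2 stands second highest of the three numbers. Its nearest neighbour is compound 3, whose number lies within the scatter of its own, and even the furthest, compound 1, lies within the scatter. On these three numbers the compounds cannot be told apart in how much of them the cells tolerate.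

The next compound, compound 4 `O=[N+]([O-])c1ccc(/C=N\NC(=S)N(Cc2ccccc2)Cc2ccccc2)cc1`, differs from compound 2 in one place: 4-nitrophenyl in place of 2-hydroxyphenyl on a carbon with a double bond to nitrogen. Going by the values given here, no pair of measured compounds shows this change, so nothing measured says how large a step it brings.

Compound 4 is expected to give 130000 nM, between 50000 nM and 300000 nM, because compound 2 gives 166000 nM and the three measured numbers sit close together. The expected step from compound 2 to compound 4 is a 1.3-fold lower number from compound 2 to compound 4 (0.11 log units; within the scatter), a small move toward less tolerated, within or at the edge of the scatter.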

Compound 4, half-maximal cytotoxic concentration: < 155000 nM
Compound 4 was reported as a limit (the forecaster's own chance of this, stated with the estimate: 10%); the middle value is on the limit's open side.
By their numbers in this assay, from the lowest: compounds 3, 2 and 1 (each within the scatter of the next). At a limit, below all of these: compound 4.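

Compound 4 is reported in this assay as a limit, < 155000 nM, and not as a number. Going by these compounds alone, it nevertheless gives the first step that can be read at this position, the carbon with a double bond to nitrogen, where the earlier compounds offered no pair differing in one place: 4-nitrophenyl in place of 2-hydroxyphenyl brings an at least 1.0-fold lower number from compound 2 to compound 4 (0.02 log units; that floor lies within the scatter). The step therefore has only a floor and no fixed size, and what can be said of this change rests on a single reported limit: the limit of < 155000 nM in this assay, at which 1 of the 4 values shown sits.

The compounds shown leave open whether the true step from compound 2 reaches beyond the scatter, and whether any such step belongs to the loss of the 2-hydroxyphenyl group or to the arrival of the 4-nitrophenyl group. As far as these compounds go, how a 4-aminophenyl or a 4-carboxyphenyl group would stand at this place in this assay remains open as well.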